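Ring size of the acyl group on the shared core

The compounds below may be only part of what the source reports. "The series", "measured", "known", "first", "only" and "open" are said of these compounds alone.

Measured so far:
compound 1, `CCC(=O)n1nc(C)c(-c2ccc(Cl)c(Cl)c2)c1N`, 27400 nM
compound 2, `Cc1nn(C(=O)C2CCC2)c(N)c1-c1ccc(Cl)c(Cl)c1`, 2900 nM
compound 3, `Cc1nn(C(=O)C2CCCC2)c(N)c1-c1ccc(Cl)c(Cl)c1`, 41000 nM

In an assay on Sf9 cells for inhibition of mitogen-activated protein kinase kinase kinase 14 (Homo sapiens), read by ADP-Glo, with a stated time of 60 min (on this read-out higher numbers stand for weaker inhibition and lower numbers for stronger inhibition), compound 3 stands at the highest of the three numbers. Its nearest neighbour is compound 1, with the gap a 1.5-fold higher number from compound 1 to compound 3 (0.18 log units; within the scatter), so the two cannot be told apart; its furthest is compound 2, with the gap a 14-fold higher number from compound 2 to compound 3 (1.15 log units; beyond the scatter).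

The next compound is compound 4, `Cc1nn(C(=O)C2CCCCC2)c(N)c1-c1ccc(Cl)c(Cl)c1`, which differs from compound 3 by cyclohexyl in place of cyclopentyl on a carbonyl carbon. Among the compounds with values here, no measured pair carries this exact change. The two steps that bear on it are the ring-size steps around the acyl carbon: a 9.4-fold lower number from compound 1 to compound 2 (0.98 log units; beyond the scatter) and a 14-fold higher number from compound 2 to compound 3 (1.15 log units; beyond the scatter). The first grew the ring from ethyl to cyclobutyl and lowered the number; the second grew it once more and raised the number by a large margin. Only these three points exist, so a further enlargement is read as continuing the second step weakly or not at all beyond the scatter; no strong fall is expected.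

Compound 4 is therefore expected to give 55000 nM in this assay, with a range from 15000 nM to 200000 nM. This corresponds to an expected step of a 1.3-fold higher number from compound 3 to compound 4 (0.13 log units; within the scatter).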

Compound 4, half-maximal inhibitory concentration: 3300 nM
Compound 4: the middle estimate sits 17-fold (1.22 log units) above what was measured; measured number below the stated range.
By their numbers in this assay, from the lowest: compounds 2 and 4 (each within the scatter of the next); then compounds 1 and 3 (each within the scatter of the next).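

Notes on the acyl ring: in this assay the number does not rise steadily with ring size on this carbonyl carbon, since cyclohexyl in place of cyclopentyl gives a 12-fold lower number from compound 3 to compound 4 (1.09 log units; beyond the scatter) and so reverses the rise seen on going to the cyclopentyl of compound 3. The cyclohexyl ring matches the cyclobutyl ring with a 1.1-fold higher number from compound 2 to compound 4 (0.06 log units; within the scatter) and stands clear of the ethyl group with an 8.3-fold lower number from compound 1 to compound 4 (0.92 log units; beyond the scatter), so the four compounds fall into two sets that do not follow ring size: compound 2 with compound 4 at the lower numbers, compound 1 with compound 3 at the higher. No measurement at hand explains why the cyclopentyl ring parts from the rings on either side of it in size.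

Open, going by these compounds, is whether this alternation continues to a cycloheptyl ring or extends down to a cyclopropyl ring on the same carbonyl carbon. Also open, on these data alone, is whether the lower numbers of the cyclobutyl and cyclohexyl compounds survive a ring oxygen, as in tetrahydropyranyl, or a ring amine, as in piperidinyl.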